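Extending the distal phenyl: sulfonyl to butyl

This account rests on a few compounds, and the source may have more. Where it says the series, first, only, none or still open, it means among the compounds named here.

Compound 1, `COc1cc2nc(N3CCN(S(=O)(=O)c4ccc([N+](=O)[O-])cc4)CC3)nc(N)c2cc1OC`, gives 36000 nM in a functional assay on PC-3 cells (Homo sapiens) for inhibition; a higher number here means a weaker inhibitor, a lower number a stronger inhibitor. Compound 2, `COc1cc2nc(N3CCN(S(=O)(=O)c4ccc(-c5ccc(S(C)(=O)=O)cc5)cc4)CC3)nc(N)c2cc1OC`, carries a 4-(methylsulfonyl)phenyl in place of the nitro group on the aromatic carbon, and in this assay compound 2 gives 7200 nM. Going by the values given here, that single step, a 5.0-fold lower number from compound 1 to compound 2 (0.70 log units; beyond the scatter), is the only measured step, and it leaves compound 2 with the lowest of the two numbers so far.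

Compound 3, `CCCCc1ccc(-c2ccc(S(=O)(=O)N3CCN(c4nc(N)c5cc(OC)c(OC)cc5n4)CC3)cc2)cc1`, differs from compound 2 in one place: butyl in place of methylsulfonyl on an aromatic carbon. Among the compounds with values here, no measured pair replaces a methylsulfonyl by an alkyl chain on this ring, so the step from compound 1 to compound 2 does not bear directly on it; it only shows that the distal phenyl ring is tolerated. Within the data shown here, with no comparable step to lean on, the working expectation is that compound 3 lands near compound 2, within the scatter, so the step is estimated as a 1.1-fold lower number from compound 2 to compound 3 (0.04 log units; within the scatter). Compound 3 is therefore expected at about 6500 nM in this assay, in a range from 1500 nM to 28000 nM.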

Compound 3, half-maximal inhibitory concentration: 3400 nM
Compound 3: the middle estimate sits 1.9-fold (0.28 log units) above what was measured; the measured number falls inside the stated range.
By their numbers in this assay, from the lowest: compound 3; then compound 2; then compound 1.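

Notes on the distal ring: in this assay, the group on this aromatic carbon, para to a large group, changes the number by itself, and butyl in place of methylsulfonyl gives a 2.1-fold lower number from compound 2 to compound 3 (0.33 log units; beyond the scatter) with the heavy-atom count unchanged at 4. The hydrogen-bond acceptors of methylsulfonyl are therefore not required at this position for the activity seen so far, since compound 3 has none in this group and still has the lower number. Going by these compounds alone, measured against the nitro compound, the full change to 4-butylphenyl gives an 11-fold lower number from compound 1 to compound 3 (1.02 log units; beyond the scatter) and is the only step so far that is printed as large, but nothing on hand accounts for the shift from methylsulfonyl to butyl.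

This single pair cannot separate a benefit from butyl from a penalty carried by methylsulfonyl, and a bare distal phenyl with only hydrogen at this carbon would be needed to tell the two apart. As far as these compounds go, it also remains open whether a longer chain such as hexyl continues the trend, and whether an amine or a carboxylic acid on the same carbon is tolerated in this assay at all.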